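Aryl swap on the shared core: cytotoxicity notes

The source may report more compounds than this note shows. Statements on the series, on what has been measured and on what is new or still open speak of the compounds shown alone.

Compound 1 `COc1cccc(-c2cnc(NC(=O)c3ccc(F)cc3)n2C)c1` in a toxicity assay on THP-1 cells (Homo sapiens) for inhibition (a lower number here means that less compound is tolerated, a higher number that more compound is tolerated), gives > 100000 nM, which is a limit of the assay and not a number.
Compound 2 `Cc1ccccc1-c1cnc(NC(=O)c2ccc(F)cc2)n1C` in this assay gives > 50000 nM, again a limit rather than a number.
Compound 3 `Cn1c(-c2ccc(F)cc2)cnc1NC(=O)c1ccc(F)cc1` in this assay gives > 100000 nM, also a limit.

Compound 3 thus stands on a limit only, and the two further values shown are limits as well. The step that the two limits leave unreadable from compound 1 to compound 3 cannot be read, nor can a step that the two limits leave unreadable from compound 2 to compound 3 or a step that the two limits leave unreadable from compound 1 to compound 2: each runs between two limits, the one marked by the limit of > 100000 nM in this assay, at which 2 of the 3 values shown sit, and the one marked by the limit of > 50000 nM in this assay, at which 1 of the 3 values shown sits, so its size is not known.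

Compound 4 `Cn1c(-c2ccccc2Br)cnc1NC(=O)c1ccc(F)cc1` differs from compound 3 by 2-bromophenyl in place of 4-fluorophenyl on an aromatic carbon. Among the compounds with values here, none of the measured steps gives a readable size for an aryl swap at this place; all three say only that the series sits at or beyond the tested range. On that basis no step beyond the scatter is expected in this assay, and the expected step is a number no higher from compound 3 to compound 4 (the limit leaves the size open). Compound 4 is estimated at 100000 nM, in a range from 50000 nM to 200000 nM, most probably reported again as a limit.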

Compound 4, half-maximal cytotoxic concentration: > 100000 nM
Compound 4 was reported as a limit; the forecaster's own chance of this, stated with the estimate: 80%; the middle value sits exactly at the limit.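

In this assay compound 4 gives > 100000 nM, a limit of the assay and not a number. Its steps to compound 1, compound 2 and compound 3 cannot be read, each ending on a limit: the limit of > 100000 nM in this assay, at which 3 of the 4 values shown sit.

The compounds shown leave open how much of any of these four compounds is tolerated, and whether the aryl swaps change that at all.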